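The compounds below may be only part of what the source reports. "The series", "measured", "known", "first", "only" and "open" are said of these compounds alone.

Of the compounds shown here, three have been measured in a functional assay on CHO cells for agonist activity at metabotropic glutamate receptor 2 (Homo sapiens), read by GTPgammaS binding; a lower number here means that less compound is needed, a higher number that more compound is needed for the effect. Compound 1 `Cn1ccc2cc(-c3ccn4c(CC(F)(F)F)cnc4c3C#N)ccc21` gives 230 nM, compound 2 `FC(F)(F)Cc1cnc2c(Cl)c(-c3cc(Cl)c4c(ccn4CC4CC4)c3)ccn12` gives 250 nM, and compound 3 `N#Cc1c(-c2ccc3c(c2)OCCN3)ccn2c(CC(F)(F)F)cnc12` gives 1660 nM. Compound 2 thus stands second highest of the three, within the scatter of compound 1 and well beyond it from compound 3. The next compound, compound 4 `FC(F)(F)Cc1cnc2c(Cl)c(-c3cc(Cl)c4[nH]ccc4c3)ccn12`, has not been measured. It differs from compound 2 by hydrogen in place of cyclopropylmethyl on an aromatic nitrogen, that is, a hydrogen in place of cyclopropylmethyl on an aromatic nitrogen. Within the data shown here, no measured pair shows this change, so the step is expected on general grounds to be a modest rise in the number, a 2.2-fold higher number from compound 2 to compound 4 (0.34 log units; beyond the scatter). Compound 4 is therefore estimated at 550 nM, with a likely range from 160 nM to 1900 nM.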

Compound 4, half-maximal effective concentration: 85 nM
Compound 4: the middle estimate sits 6.5-fold (0.81 log units) above what was measured, outside the stated range (below it).
By their numbers in this assay, from the lowest: compound 4; then compounds 1 and 2 (each within the scatter of the next); then compound 3.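

Hydrogen in place of cyclopropylmethyl on the aromatic nitrogen gives, in this assay, a 2.9-fold lower number from compound 2 to compound 4 (0.47 log units; beyond the scatter) and so moves the series to its lowest number. Among these compounds, the effect therefore does not depend on cyclopropylmethyl at this place, and this pair is the first direct reading of a change there. Nothing measured on these compounds accounts for the step.

Still open, as far as these compounds go, is whether an ethyl group or a chain ending in an amine on this nitrogen would sit nearer compound 4 or compound 2. From the compounds shown here alone, it is also open whether the step would be the same size on the core of compound 1, which carries a nitrile.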